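Aryl amine variation on a shared core, compounds 2 and 3

This account rests on a few compounds, and the source may have more. Where it says the series, first, only, none or still open, it means among the compounds named here.

Measured so far:
compound 1 `Cc1cccc(Nc2nc3nonc3nc2Nc2ccccc2F)c1`: 1500 nM
compound 2 `Cc1ccc(Nc2nc3nonc3nc2Nc2ccccc2F)cc1`: 2100 nM

Compound 2 and compound 1 sit within the scatter of each other in an assay on mitochondria from L6 cells (Rattus norvegicus) for activation, with a stated time of 90 min; a lower number here means that less compound is needed, a higher number that more compound is needed for the effect; a 1.4-fold higher number from compound 1 to compound 2 (0.15 log units; within the scatter), with 4-methylphenyl in place of 3-methylphenyl on a nitrogen on an aromatic ring. Compound 3 `CCOc1cccc(Nc2nc3nonc3nc2Nc2ccccc2F)c1` differs from compound 2 thus: 3-ethoxyphenyl in place of 4-methylphenyl on a nitrogen on an aromatic ring. Among the measured compounds shown here, the one measured step bears only loosely on this change and stayed within the scatter, and nothing measured covers an ethoxy group. No step beyond the scatter is therefore expected; the estimated step is a 1.3-fold lower number from compound 2 to compound 3 (0.12 log units; within the scatter). Compound 3 is expected at 1600 nM, range 600 nM to 4500 nM.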

Compound 3, half-maximal effective concentration: 2200 nM
Compound 3: middle estimate off by 1.4-fold (0.14 log units), on the low side; low and high end bracket the measured number.
By their numbers in this assay, from the lowest: compounds 1, 2 and 3 (each within the scatter of the next).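

In this assay the entry of 3-ethoxyphenyl for 4-methylphenyl, which brings in an oxygen and a hydrogen-bond acceptor, gives a 1.0-fold higher number from compound 2 to compound 3 (0.02 log units; within the scatter). Ethoxy in place of methyl on an aromatic carbon gives a 1.5-fold higher number from compound 1 to compound 3 (0.17 log units; within the scatter), so compounds 1, 2 and 3 show no step beyond the scatter at this aryl amine. No evidence on the cause of these small steps is available.

Still open, as far as these compounds go, is whether an amine, a carboxylic acid or a longer chain on this ring would give a step beyond the scatter. The other aryl amine on the shared core also remains unresolved.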